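Swapping the amide substituent: from cyclohexyl to pyrazolyl

The source may hold more compounds than are shown below. What is called first, only, known or untested is meant among the compounds shown, and "the series" means these compounds.

Measured compounds:
compound 1, `CCN(Cc1ccc(C)s1)C(=O)COc1ccc(C)cc1`, 178 nM
compound 2, `CCN(Cc1cccs1)C(=O)c1cc2cc(C)ccc2o1`, 120 nM
compound 3, `Cc1ccc(OCC(=O)N(Cc2cccs2)C2CCCCC2)cc1`, 40000 nM

Of the three compounds measured in an assay on HEK293 cells for agonist activity at transient receptor potential cation channel subfamily M member 8 (Homo sapiens), read by fluorescence and calcium flux, with a stated time of 15 min (a higher number here means that more compound is needed for the effect, a lower number that less compound is needed), compound 3 stands highest: compound 3 gives 40000 nM, compound 1 gives 178 nM and compound 2 gives 120 nM. The gaps from compound 3 to each of the other two lie outside the usual scatter. The two lower values belong to compounds that carry an ethyl group on the amide-type nitrogen, whereas compound 3 carries a cyclohexyl there.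

Compound 4, `Cc1ccc(OCC(=O)N(Cc2cccs2)c2ccn[nH]2)cc1`, keeps the rest of compound 3 and differs only in one place: 1H-pyrazol-5-yl in place of cyclohexyl on an amide-type nitrogen. No single change of this kind has been measured in this set, so the expectation rests on the contrast between compound 3 and the two ethyl-bearing compounds. Because compound 1 gives 178 nM while compound 3 gives 40000 nM, a smaller substituent on that nitrogen is expected to bring the number down, though a pyrazolyl is not an ethyl and the step is expected to be modest. Compound 4 is thus expected to give 8000 nM in this assay, within a range of 1000 nM to 40000 nM, which would mean an expected step of a 5.0-fold lower number from compound 3 to compound 4 (0.70 log units; beyond the scatter).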

Compound 4, half-maximal effective concentration: 0.2 nM
Beside the measured number, compound 4's estimate is 40000-fold (4.60 log units) above it; measured number below the stated range.
By their numbers in this assay, from the lowest: compound 4; then compounds 2 and 1 (each within the scatter of the next); then compound 3.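

In this assay the exchange of cyclohexyl for 1H-pyrazol-5-yl on the amide-type nitrogen gives a 200000-fold lower number from compound 3 to compound 4 (5.30 log units; beyond the scatter) with the rest of the molecule unchanged. This shows that this one place can, on its own, shift the number by a very large step, which compound 1, compound 2 and compound 3 could not show, as they differ from one another in more than one place. The entering group is aromatic, contains nitrogen and counts a hydrogen-bond donor and acceptor, but no measurement at hand bears on what lies behind the step.

From the compounds shown here alone, whether a phenyl ring, or a pyrazolyl carrying a methyl on its ring nitrogen, would give a similarly low number on that nitrogen remains open. Going by these compounds, it also remains open whether the same exchange would have a comparable effect with the ethyl-bearing cores.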